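Swapping a short chain for a fluorinated ring

The compounds below may be only part of what the source reports. "The series", "measured", "known", "first", "only" and "open" are said of these compounds alone.

Of the compounds shown here, three sharing one core have been tested in a functional assay on RAW264.7 cells (Mus musculus) for inhibition, read by Griess assay, with stated times of 2 h and 24 h; a higher number here means a weaker inhibitor, a lower number a stronger inhibitor. Compound 1 `COc1ccc([C@@H]2CC(=O)c3c(O)cc(OCc4cn(Cc5ccccc5C(F)(F)F)nn4)cc3O2)cc1O` gives 12500 nM. Compound 2 `COc1ccc([C@@H]2CC(=O)c3c(O)cc(OCc4cn(Cc5ccccc5)nn4)cc3O2)cc1O` gives 11000 nM. Compound 3 `CCCn1cc(COc2cc(O)c3c(c2)O[C@H](c2ccc(OC)c(O)c2)CC3=O)nn1` gives 9670 nM, the lowest of the three numbers, yet all three sit within the scatter of one another, so no ranking can be drawn among them.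

Compound 4 `COc1ccc([C@@H]2CC(=O)c3c(O)cc(OCc4cn(Cc5ccccc5F)nn4)cc3O2)cc1O` has not yet been measured. It differs from compound 3 in one place: 2-fluorophenyl in place of ethyl on a saturated chain carbon bound to an aromatic nitrogen.

Among the compounds with values here, two measured steps bear on this change, both running in the opposite direction, from an aromatic ring on that chain carbon to a plain chain. The step of a 1.1-fold lower number from compound 2 to compound 3 (0.06 log units; within the scatter) and the step of a 1.3-fold lower number from compound 1 to compound 3 (0.11 log units; within the scatter) were both small, inside the scatter. Reversing that kind of move, and adding a fluorine to the ring that enters, gives no reason to expect anything beyond the scatter in this assay.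

Compound 4 is therefore expected to land near compound 3, with the step of a 1.1-fold higher number from compound 3 to compound 4 (0.06 log units; within the scatter) being the estimate. The estimated value for compound 4 in this assay is 11000 nM, with a range from 6000 nM to 20000 nM.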

Compound 4, half-maximal inhibitory concentration: 7320 nM
The estimate for compound 4 lay 1.5-fold (0.18 log units) above the measured number; the measured number falls inside the stated range.
By their numbers in this assay, from the lowest: compounds 4, 3, 2 and 1 (each within the scatter of the next).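

In this assay the step of a 1.3-fold lower number from compound 3 to compound 4 (0.12 log units; within the scatter) shows that a fluorinated ring can stand on this saturated chain carbon bound to an aromatic nitrogen without the reading separating from that of the plain chain. On the ring itself, the steps of a 1.5-fold lower number from compound 2 to compound 4 (0.18 log units; within the scatter) and a 1.7-fold lower number from compound 1 to compound 4 (0.23 log units; within the scatter) complete a comparison of hydrogen, fluoro and trifluoromethyl at the same ring carbon, and even the larger of these two steps stays inside the scatter, so the assay separates none of the three groups. No measured property of these compounds is available to account for the numbers.

What stays open is whether any group at this place can move the number beyond the scatter at all, since every compound shown so far sits within the scatter of its neighbour in the ranking. A carboxylic acid or an amine on the benzyl ring, or a chain longer than propyl on the same nitrogen, would test this, and the four compounds here say nothing about how such groups would read.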